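Cyano in place of ethoxycarbonyl on the shared core

A few compounds are considered here, and "the series" means these few. Any claim that something is new, unique, unknown or untested is made for them only; others in the source may bear on it.

Of the compounds shown here, three have been read so far in a functional assay on the whole organism for inhibition, with Cavia porcellus as the target; on this read-out lower numbers stand for an effect already at smaller amounts and higher numbers for an effect only at larger amounts of compound. Compound 1 `CCOC(=O)Cc1cn2cc(Br)nc(Br)c2n1` gives 21 nM. Compound 2 `CCOC(=O)c1cn2c(Br)cncc2n1` gives 52 nM, the higher of the two numbers, and its gap to compound 1 lies beyond the usual scatter. Compound 3 `NC(=O)c1cn2ccncc2n1` is recorded as a limit, > 56 nM, and not as a number, so it cannot be ranked against the other two.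

The next compound to be read is compound 4 `N#Cc1cn2c(Br)cncc2n1`, which departs from compound 2 in one place. It carries cyano in place of ethoxycarbonyl on an aromatic carbon of the five-membered aromatic ring with 2 nitrogen (cyano in place of ethoxycarbonyl on an aromatic carbon). Among the measured compounds shown here, no measured pair isolates a change at this carbon, so any expectation in this assay is anchored on compound 2 at 52 nM and carries a wide margin. No shift in either direction beyond the usual scatter is expected. The estimated 1.0-fold lower number from compound 2 to compound 4 (0.02 log units; within the scatter) is therefore expected to be small. For compound 4 the expected value is 50 nM, with an estimated range from 15 nM to 170 nM.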

Compound 4, concentration for half-maximal effect: > 15 nM
Compound 4 ended at the assay's limit; the forecaster's own chance of this, stated with the estimate: 20%; the middle value is on the limit's open side.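

In this assay compound 4 is recorded as a limit, > 15 nM, not as a number. Among the compounds shown here, no step from compound 2 to compound 4 can therefore be read. The compounds shown leave open whether cyano in place of ethoxycarbonyl on an aromatic carbon shifts the number in this assay at all, and in which direction.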